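Swapping the aromatic ring on a shared bicyclic core

This account rests on a few compounds, and the source may have more. Where it says the series, first, only, none or still open, it means among the compounds named here.

Measured so far:
compound 1, `COc1cc(F)ccc1-c1ccnc2[nH]c(C3CCOCC3)cc12`: 10 uL/min
compound 2, `CC(C)n1cc(-c2ccnc3[nH]c(C4CCN(CC(=O)N(C)C)CC4)cc23)cnc1=O`: 24 uL/min

In an ADME assay on microsomes from liver (Homo sapiens) for metabolic stability (a higher number here means faster removal of the compound, a lower number slower removal), compound 2 gives 24 uL/min, the higher of the two numbers; compound 1 gives 10 uL/min, and that gap lies beyond the usual scatter. Compound 3, `COc1cc(=O)n(C)cc1-c1ccnc2[nH]c(C3CCN(CC(=O)N(C)C)CC3)cc12`, has not been measured. It differs from compound 2 by a group of 10 heavy atoms (7 carbon, 1 nitrogen, 2 oxygen; one six-membered aromatic ring with 1 hetero atom) in place of a group of 10 heavy atoms (7 carbon, 2 nitrogen, 1 oxygen; one six-membered aromatic ring with 2 hetero atoms), on an aromatic carbon. Going by the values given here, no measured pair shows this exact change, so only a modest step is expected, if any, in this assay. Compound 3 is expected to give 18 uL/min, with a likely range from 9 uL/min to 36 uL/min. That estimate means a step of a 1.3-fold lower number from compound 2 to compound 3 (0.12 log units; within the scatter), expected to sit within the scatter.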

Compound 3, intrinsic clearance in a liver preparation (reported as CLH), per the amount of preparation that the assay uses: < 3 uL/min
Compound 3 was reported as a limit; the forecaster's own chance of this, stated with the estimate: 5%; at least 6.0-fold (0.77 log units) between middle value and limit.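

In this assay, exchanging one six-membered aromatic ring for another on this aromatic carbon, opposite the ring nitrogen, gives an at least 8.0-fold lower number from compound 2 to compound 3 (0.90 log units; beyond the scatter). Both groups have 10 heavy atoms, so this position responds strongly to the make-up of the ring, not only to its size. The value for compound 3 is a limit of the assay, not a number: the limit of < 3 uL/min in this assay, at which 1 of the 3 values shown sits.

This single pair does not separate the methoxy group from the change in the ring itself. From the compounds shown here alone, how a ring carrying an amine or a nitrile in place of the methoxy group would behave here remains open.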